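The source may hold more compounds than are shown below. What is called first, only, known or untested is meant among the compounds shown, and "the series" means these compounds.

Compound 1 `CC(C)n1cnc2c(Nc3ccccc3)nc(NCOCc3ccc(C(=O)Nc4ccccc4N)cc3)nc21`, compound 2 `CCCCn1cnc2c(Nc3cccc(Cl)c3)nc(NCOCc3ccc(/C=C/C(=O)Nc4ccccc4N)cc3)nc21` and compound 3 `CC(C)n1cnc2c(Nc3ccccc3)nc(NCOCc3ccc(/C=C/C(=O)Nc4ccccc4N)cc3)nc21` have been measured in a functional assay on NCI-H460 cells (Homo sapiens) for antiproliferative activity, read by CCK-8 assay, with a stated time of 72 h, tested at 8 uM; a lower number here means a weaker effect, a higher number a stronger effect of the compound at the concentration tested. Compound 1 gives 34.3%, compound 2 gives 51.1% and compound 3 gives 53.1%.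

Compound 3 shows the highest of the three numbers, but compound 2 lies within the scatter of it, so neither can be called the stronger; compound 1 lies clearly lower, by the step of a number 18.8 percentage points higher from compound 1 to compound 3 (beyond the scatter). Compound 4 `CCCCn1cnc2c(Nc3ccccc3)nc(NCOCc3ccc(/C=C/C(=O)Nc4ccccc4N)cc3)nc21` differs from compound 3 by butyl in place of isopropyl on an aromatic nitrogen. Among the compounds with values here, no measured step isolates this change. Compound 2 carries a butyl on that nitrogen yet differs from compound 3 in a second place as well, and its value and that of compound 3 sit within the scatter. The expected step of a number 1.1 percentage points lower from compound 3 to compound 4 (within the scatter) is therefore none beyond the scatter. Compound 4 is estimated at 52%, within 40% to 64%.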

Compound 4, a percentage reported as inhibition, at one concentration (the size of the read-out at that concentration, not a potency): 34.2%
The estimate for compound 4 lay 17.8 percentage points above the measured number; measured number below the stated range.
By their numbers in this assay, from the lowest: compounds 4 and 1 (each within the scatter of the next); then compounds 2 and 3 (each within the scatter of the next).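

In this assay, the group on the aromatic nitrogen matters: the change shows as a number 18.9 percentage points lower from compound 3 to compound 4 (beyond the scatter) when butyl replaces isopropyl. The chloro group matters too, with a number 16.9 percentage points lower from compound 2 to compound 4 (beyond the scatter) when hydrogen replaces it and butyl stays, so the closeness of compound 2 and compound 3 had concealed two separate effects. No supporting data explain either step. Open, going by these compounds, is whether a propyl or cyclopentyl group on that nitrogen would follow isopropyl or butyl. Also open, on these data alone, is whether chloro would change the value of an isopropyl compound.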